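Fluoro for hydrogen on the aryl ring: efficacy notes

A few compounds are considered here, and "the series" means these few. Any claim that something is new, unique, unknown or untested is made for them only; others in the source may bear on it.

Measured so far:
compound 1 `O=C(O)Cc1sc(C(c2ccccc2)c2ccccc2)nc1-c1ccccc1` — 80%
compound 2 `O=C(O)Cc1sc(C(c2ccc(F)cc2)c2ccc(F)cc2)nc1-c1ccoc1` — 80%

In an in vitro functional assay on HEK285-7 cells for antagonist activity at prostaglandin D2 receptor 2 (Homo sapiens), read by BRET and beta-arrestin recruitment (on this read-out lower numbers stand for smaller maximal responses and higher numbers for larger maximal responses), compound 1 gives 80%. Compound 2 gives 80% in this assay, so compound 1 stands level with compound 2 at the digits shown, the two maximal responses lying within the scatter of each other. For the measured compounds named here, compound 1 and compound 2 differ in more than one place, so no single step between them can be counted; their values simply show the same maximal response from two rather different structures.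

Compound 3 `O=C(O)Cc1sc(C(c2ccccc2)c2ccccc2)nc1-c1cccc(F)c1` has not yet been run in this assay. It differs from compound 1 by fluoro in place of hydrogen on an aromatic carbon. Going by the values given here, no measured pair isolates a change of this kind, so nothing in the data points toward a rise or a fall in maximal response. The step from compound 1 to compound 3 is therefore expected to be no change at the digits printed from compound 1 to compound 3 (within the scatter), nothing beyond the scatter in either direction. For compound 3 the maximal response in this assay is estimated at 80%, with a range from 65% to 95%.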

Compound 3, largest response reached (reported as efficacy), in percent of the reference or control that the assay uses: 80%
The estimate for compound 3 equals the measured number at the digits printed, within the range that was stated.
By their numbers in this assay, from the lowest: compounds 1, 2 and 3 (each within the scatter of the next).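

In this assay, for the compounds shown here, the pair of compound 1 and compound 3 is the first to differ in one place, and it gives no change at the digits printed from compound 1 to compound 3 (within the scatter) for fluoro in place of hydrogen on an aromatic carbon. On this six-membered aromatic ring of carbon only, meta to a large group, the turn from phenyl to 3-fluorophenyl thus leaves the maximal response level, something compound 1 and compound 2 could not show, as they differ in more than one place. No measurement at hand speaks to the reason for this result.

From the compounds shown here alone, whether the maximal response also stays level with a heavier replacement at this place, such as chloro, methoxy or an amine, remains open, as does the effect of fluoro on the other carbons of this ring. The result also rests on maximal response alone in this assay, so it leaves open whether compound 3 and compound 1 match on any other measure, and whether the same step would read alike on the core of compound 2.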